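Cytotoxicity of Benzyloxy Chalcones: From Nitro to Trichloro

The compounds below may be only part of what the source reports. "The series", "measured", "known", "first", "only" and "open" are said of these compounds alone.

Compounds measured so far:
- compound 1, `O=C(/C=C/c1cccc(OCc2ccccc2)c1)c1ccc(Br)cc1`: 9000 nM
- compound 2, `O=C(/C=C/c1cccc(OCc2ccccc2)c1)c1ccc(Cl)cc1Cl`: 27500 nM
- compound 3, `O=C(/C=C/c1cccc(OCc2ccccc2)c1)c1ccc([N+](=O)[O-])cc1`: 82400 nM

In an ADME assay on CHO cells (Cricetulus griseus) for cytotoxicity, read by MTT assay, with a stated time of 68 h (on this read-out lower numbers stand for stronger inhibition and higher numbers for weaker inhibition), compound 3 gives 82400 nM, the highest number among the three measured compounds; its nearest neighbour is compound 2 at 27500 nM, and compound 1 at 9000 nM lies furthest from it. The two steps leading to compound 3 are both beyond the scatter: a 9.2-fold higher number from compound 1 to compound 3 (0.96 log units; beyond the scatter) and a 3.0-fold higher number from compound 2 to compound 3 (0.48 log units; beyond the scatter), so on these numbers compound 3 is the least cytotoxic of the set.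

Compound 4, `O=C(/C=C/c1cccc(OCc2ccccc2)c1)c1ccc(Cl)c(Cl)c1Cl`, has not yet been measured. Its change from compound 3 is 2,3,4-trichlorophenyl in place of 4-nitrophenyl on a carbonyl carbon. Going by the values given here, the step that bears most directly on it is the one from compound 2 to compound 3, in which a nitrophenyl replacing a chlorinated phenyl raised the number modestly; the step of a 3.1-fold higher number from compound 1 to compound 2 (0.49 log units; beyond the scatter) shows that the dichlorophenyl itself sat above the bromophenyl. Reversing the nitro-to-chloro direction, compound 4 is expected to come back toward the region of compound 2, with a 3.3-fold lower number from compound 3 to compound 4 (0.52 log units; beyond the scatter). Compound 4 is therefore estimated at 25000 nM in this assay, with a range from 9000 nM to 70000 nM.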

Compound 4, half-maximal inhibitory concentration: 8600 nM
Compound 4: the middle estimate sits 2.9-fold (0.46 log units) above what was measured; measured number below the stated range.
By their numbers in this assay, from the lowest: compounds 4 and 1 (each within the scatter of the next); then compound 2; then compound 3.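

In this assay the 2,3,4-trichlorophenyl on the carbonyl carbon, in place of 4-nitrophenyl, gives a 9.6-fold lower number from compound 3 to compound 4 (0.98 log units; beyond the scatter) and so shows that a chlorinated phenyl at this place can reach well below the only one seen before, the 2,4-dichlorophenyl of compound 2. A single chloro in place of hydrogen on an aromatic carbon accounts for a 3.2-fold lower number from compound 2 to compound 4 (0.50 log units; beyond the scatter) within this pair, so the pattern of chloro groups on this ring changes the number by more than the scatter, while the comparison with the 4-bromophenyl gives a 1.0-fold lower number from compound 1 to compound 4 (0.02 log units; within the scatter) and places the trichlorophenyl and bromophenyl compounds level in this assay. No measurement at hand offers an explanation for these shifts.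

The compounds shown leave open whether other groups on this phenyl, such as a methoxy, an amine or a single fluoro, would fall with compounds 1 and 4 or nearer compound 3. They also leave open whether the steps seen here would hold with a change elsewhere on the shared core, for instance a carboxylic acid in place of the benzyl group.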